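The compounds below may be only part of what the source reports. "The series", "measured", "known", "first", "only" and "open" are said of these compounds alone.

Measured compounds:
compound 1, `CCCc1cc(N2CCC2)c2cc(NC(=O)/C=C/c3ccc(C(F)(F)F)cc3)ccc2n1`, gives 2500 nM in a functional assay on HEK293 cells for activation of melanin-concentrating hormone receptor 1 (Homo sapiens), read by inositol phosphate accumulation; a lower number here means that less compound is needed, a higher number that more compound is needed for the effect
compound 2, `CCCc1cc(N(C)C)c2cc(NC(=O)/C=C/c3ccc(C(F)(F)F)cc3)ccc2n1`, gives 300 nM in this assay

Going by the values given here, compound 2 stands at the lowest number of the two measured in this assay; its nearest neighbour is compound 1, and the only measured step, an 8.3-fold lower number from compound 1 to compound 2 (0.92 log units; beyond the scatter), separates them.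

The next compound, compound 3 `CCCc1cc(OC)c2cc(NC(=O)/C=C/c3ccc(C(F)(F)F)cc3)ccc2n1`, is reached from compound 2 by methoxy in place of dimethylamino on an aromatic carbon. The only step that bears on this position is the one from compound 1 to compound 2, where one amine replaced another on the same aromatic carbon and the number fell by the amount given above. That step shows the position tolerates a change of substituent with a sizeable effect on the number, but it gives no direct guide to swapping an amine for an oxygen-linked group. Without a closer precedent, a step in either direction is possible; the working expectation is a moderate rise in the number, a 2.3-fold higher number from compound 2 to compound 3 (0.37 log units; beyond the scatter), with wide uncertainty. Compound 3 is therefore estimated at 700 nM, in the range 150 nM to 3500 nM.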

Compound 3, half-maximal effective concentration: 360 nM
Compound 3: middle estimate off by 1.9-fold (0.29 log units), on the high side; measured number inside the range.
By their numbers in this assay, from the lowest: compounds 2 and 3 (each within the scatter of the next); then compound 1.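

In this assay, methoxy in place of dimethylamino on the aromatic carbon opposite the ring nitrogen gives a 1.2-fold higher number from compound 2 to compound 3 (0.08 log units; within the scatter) and so shows that an oxygen-linked group and a nitrogen-linked group cannot be told apart at this position; a nitrogen attached there is not needed for a number at this level. Methoxy in place of azetidin-1-yl gives a 6.9-fold lower number from compound 1 to compound 3 (0.84 log units; beyond the scatter) and, read with an 8.3-fold lower number from compound 1 to compound 2 (0.92 log units; beyond the scatter) as well, this sets azetidin-1-yl apart as the one group of the three with a gap beyond the scatter to both of the others. No measurement on these compounds offers an explanation for this pattern.

Still open, on these data alone, is how far this tolerance extends on the same carbon, for example to ethoxy, a chlorine atom, pyrrolidin-1-yl or plain hydrogen. Also open, as far as these compounds go, is whether methoxy and dimethylamino remain indistinguishable when the propyl group or the trifluoromethyl-bearing end of the shared core is replaced, for example by a longer chain or a nitrile.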